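The source may report more compounds than this note shows. Statements on the series, on what has been measured and on what is new or still open speak of the compounds shown alone.

Compound 1 `O=C(Nc1ccc2c(c1)N(Cc1ccc(C(=O)NO)cc1)CC2)Nc1ccc(Cl)c(C(F)(F)F)c1` gives 2800 nM in a functional assay on A549 cells (Homo sapiens) for inhibition, read by sulforhodamine B assay, with a stated time of 48 h; a higher number here means a weaker inhibitor, a lower number a stronger inhibitor.
Compound 2 `O=C(CCCCCCC(=O)Nc1ccc(NC(=O)Nc2ccc(Cl)c(C(F)(F)F)c2)cc1)NO` gives 9500 nM in this assay.

Among the compounds with values here, of the two compounds measured so far, compound 2 stands at the higher number and is therefore the weaker inhibitor; its gap to compound 1 lies beyond the usual scatter of repeated measurements. Compound 3 `O=C(CCCCCC(=O)Nc1ccc(NC(=O)Nc2ccc(Cl)c(C(F)(F)F)c2)cc1)NO` has not yet been measured in this assay. It differs from compound 2 in a single place: hydroxycarbamoyl in place of (hydroxycarbamoyl)methyl on a saturated chain carbon, five bonds along the chain from a carbonyl carbon. Both compounds keep the same shared core and the same hydroxycarbamoyl end; only the saturated chain between them is one link shorter in compound 3. Within the data shown here, no pair of measured compounds that differ in one place is available, so nothing measured here shows what such a shortening does, and the expectation rests on compound 2 and the change alone. The writer expects a small step toward a higher number, that is toward a weaker inhibitor, from compound 2 to compound 3 of a 1.5-fold higher number from compound 2 to compound 3 (0.17 log units; within the scatter), close to the edge of the scatter. For compound 3 the estimate in this assay is 14000 nM, with a range from 5000 nM to 40000 nM.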

Compound 3, half-maximal inhibitory concentration: > 10000 nM
Compound 3 gave a limit, no number (the forecaster's own chance of this, stated with the estimate: 10%); the middle value is on the limit's open side.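

In this assay compound 3 gives a limit and not a number: the limit of > 10000 nM in this assay, at which 1 of the 3 values shown sits. Hydroxycarbamoyl in place of (hydroxycarbamoyl)methyl, on a saturated chain carbon five bonds along the chain from a carbonyl carbon, now provides the first step between compounds that differ in one place, read as an at least 1.0-fold higher number from compound 2 to compound 3 (0.02 log units; that floor lies within the scatter). That figure is a floor, so the result shows that shortening this chain does not move the series to a lower number, while the true size of the step may lie anywhere from within the scatter to well beyond it.

The compounds shown leave open how far past its limit compound 3 lies, so the effect of the shortening has no measured size. They also leave open what a longer chain at this place, or a carboxylic acid in place of the hydroxycarbamoyl end, would do, and compound 1 differs from compound 2 in more than one place, so it offers no reading on either change.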